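A few compounds are considered here, and "the series" means these few. Any claim that something is new, unique, unknown or untested is made for them only; others in the source may bear on it.

Measured so far:
compound 1 `O=c1cc(-c2ccccc2)oc2cccc(OCCCCCCCN3CCC(O)CC3)c12` — 65 nM
compound 2 `CN(C)CCCCOc1ccc2oc(-c3ccccc3)cc(=O)c2c1` — 400 nM

In an assay on isolated protein (Cavia porcellus) with Sigma non-opioid intracellular receptor 1 (Homo sapiens) as the target, read by radioligand binding (a lower number here means a stronger inhibitor, a higher number a weaker inhibitor), compound 2 gives the higher of the two numbers, and its gap to compound 1 lies beyond the scatter. Compound 3 `CN(C)CCCCCCOc1ccc2oc(-c3ccccc3)cc(=O)c2c1` carries 2-(dimethylamino)ethyl in place of dimethylamino on a saturated chain carbon, four bonds along the chain from an oxygen on an aromatic ring. Going by the values given here, no measured pair shows this change, so its size is not known from the data. Compound 3 is expected to give a lower number than compound 2, a moderate step of a 3.3-fold lower number from compound 2 to compound 3 (0.52 log units; beyond the scatter), because compound 1 gives 65 nM in this assay. The estimate for compound 3 is 120 nM, with a range from 40 nM to 350 nM.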

Compound 3, half-maximal inhibitory concentration: 335 nM
Beside the measured number, compound 3's estimate is 2.8-fold (0.45 log units) below it; measured number inside the range.
By their numbers in this assay, from the lowest: compound 1; then compounds 3 and 2 (each within the scatter of the next).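

In this assay, 2-(dimethylamino)ethyl in place of dimethylamino on this saturated chain carbon, four bonds along the chain from an oxygen on an aromatic ring, gives a 1.2-fold lower number from compound 2 to compound 3 (0.08 log units; within the scatter). At this position, this two-carbon difference in the chain therefore does not separate compound 2 from compound 3 in this read-out. No available evidence bears on this result.

Still open, from the compounds shown here alone, is whether a longer chain would separate from compound 2 on the same core. Also open, going by these compounds, is what a morpholine in place of the terminal dimethylamino would give.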